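A few compounds are considered here, and "the series" means these few. Any claim that something is new, unique, unknown or untested is made for them only; others in the source may bear on it.

Compound 1 `O=C1NC(O)C(F)=CN1[C@H]1C=C[C@@H](CO)O1`: 63000 nM
Compound 2 `Nc1nc(=O)n([C@H]2C=C[C@@H](CO)O2)cc1Br`: > 100000 nM

Both compounds were tested in a functional assay on PC-3 cells (Homo sapiens) for antiproliferative activity (on this read-out lower numbers stand for stronger inhibition and higher numbers for weaker inhibition), which gives a number for compound 1 only. The entry for compound 2 is > 100000 nM, and this is a limit of the assay and not a number. Compound 2 therefore has no exact position, and the limit of > 100000 nM in this assay, at which 1 of the 2 values shown sits, is the only thing that can be said of where it stands.

Compound 3 `Nc1nc(=O)n([C@H]2C=C[C@@H](CO)O2)cc1I` differs from compound 2 in one place: iodo in place of bromo on an aromatic carbon, which is iodo in place of bromo on an aromatic carbon. For the measured compounds named here, no measured pair shows what such a change does. In this assay the expected outcome is a number no higher from compound 2 to compound 3 (the limit leaves the size open), with no estimated shift beyond the scatter in either direction. For compound 3 the estimate is 100000 nM, with an expected range of 50000 nM to 200000 nM.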

Compound 3, half-maximal inhibitory concentration: > 100000 nM
Compound 3 ended at the assay's limit; the forecaster's own chance of this, stated with the estimate: 70%; the middle value sits exactly at the limit.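

In this assay compound 2 and compound 3 each give a limit and not a number, so no step between them can be read: the limit of > 100000 nM in this assay, at which 2 of the 3 values shown sit.

From the compounds shown here alone, what iodo in place of bromo on an aromatic carbon does to antiproliferative activity therefore stays open.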